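Fluoro to trifluoromethyl on the fluorophenyl arm

The source may report more compounds than this note shows. Statements on the series, on what has been measured and on what is new or still open speak of the compounds shown alone.

Compound 1 `N#Cc1ccc(S(=O)(=O)N2C/C(=C\c3ccncc3)C(=O)/C(=C/c3ccccc3F)C2)cc1` and compound 2 `CC(=O)Nc1ccc(S(=O)(=O)N2C/C(=C\c3ccncc3)C(=O)/C(=C/c3ccccc3F)C2)cc1` share one core and differ only on the sulfonyl-bearing aromatic carbon. In a functional assay on QGY-7703 cells (Homo sapiens) for cytotoxicity, read by MTT assay, with a stated time of 24 h (on this read-out higher numbers stand for weaker inhibition and lower numbers for stronger inhibition), compound 1 gives 8500 nM, and in this assay compound 2 gives 13700 nM; the step of a 1.6-fold higher number from compound 1 to compound 2 (0.21 log units; within the scatter) is acetamido in place of cyano on an aromatic carbon. Among the compounds with values here, on the two numbers so far, compound 2 holds the higher one, though the gap to compound 1 lies within the scatter, so no order can be claimed.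

Compound 3 `CC(=O)Nc1ccc(S(=O)(=O)N2C/C(=C\c3ccncc3)C(=O)/C(=C/c3ccccc3C(F)(F)F)C2)cc1` takes the change trifluoromethyl in place of fluoro on an aromatic carbon from compound 2, placed on an aromatic carbon of a six-membered aromatic ring of carbon only, ortho to a large group; one bond further out it reads 2-fluorophenyl to 2-(trifluoromethyl)phenyl. Within the data shown here, no measured step touches this position: the single step from compound 1 to compound 2 sits on the other aromatic ring and was itself within the scatter, so it gives no direction here. The expectation for this assay is therefore no step beyond the scatter, a 1.1-fold lower number from compound 2 to compound 3 (0.02 log units; within the scatter) being the estimated movement. Compound 3 is estimated at 13000 nM, with a range from 5000 nM to 35000 nM.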

Compound 3, half-maximal inhibitory concentration: 5560 nM
Compound 3: middle estimate off by 2.3-fold (0.37 log units), on the high side, and the stated range covers the measured number.
By their numbers in this assay, from the lowest: compounds 3, 1 and 2 (each within the scatter of the next, the first and the last beyond it).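

Within the data shown here, this is the first change at the 2-fluorophenyl arm, and in this assay trifluoromethyl in place of fluoro gives a modest move beyond the scatter (a 2.5-fold lower number from compound 2 to compound 3 (0.39 log units; beyond the scatter)). Among these compounds, the earlier step (a 1.6-fold higher number from compound 1 to compound 2 (0.21 log units; within the scatter)) sat on the other aromatic ring and stayed within the scatter, so this aromatic carbon, ortho to a large group, is the first place where a single change registers. No measurement at hand accounts for the shift, which rests on one pair of compounds.

The compounds shown leave open whether a chloro or methoxy group on this carbon would read like fluoro or like trifluoromethyl. Also open, as far as these compounds go, is whether the same step holds when the nitrile of compound 1 replaces the acetamido group, or with a carboxylic acid at that place.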